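This account rests on a few compounds, and the source may have more. Where it says the series, first, only, none or still open, it means among the compounds named here.

Measured so far in a functional assay on HUVEC cells (Homo sapiens) for inhibition, with stated times of 2 h and 72 h; a higher number here means a weaker inhibitor, a lower number a stronger inhibitor 
- compound 1 `COc1cc2nccc(Oc3ccc4c(NC(=O)c5cccc(C(F)(F)F)c5)nn(C)c4c3)c2cc1OC` gives 9 nM
- compound 2 `COc1ccc(NC(=O)Nc2nn(C)c3cc(Oc4ccnc5cc(OC)c(OC)cc45)ccc23)cc1` gives 7 nM

These two values lie within the scatter of each other, so compound 2 stands level with compound 1 and the pair cannot be ranked.

Still unmeasured is compound 3 `COc1cc2nccc(Oc3ccc4c(NC(=O)c5ccc(C(F)(F)F)cc5)nn(C)c4c3)c2cc1OC` and its difference from compound 2 is 4-(trifluoromethyl)phenyl in place of (4-methoxyphenyl)amino on a carbonyl carbon with 4-(trifluoromethyl)phenyl in place of (4-methoxyphenyl)amino on a carbonyl carbon.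

Among the measured compounds shown here, one measured step bears on this change, as it falls on the same carbonyl carbon. It is a 1.3-fold lower number from compound 1 to compound 2 (0.11 log units; within the scatter) with (4-methoxyphenyl)amino in place of 3-(trifluoromethyl)phenyl. For the measured compounds named here, no compound carrying 4-(trifluoromethyl)phenyl has been measured, so this guide is only partial and the range is kept wide. With that single step as the basis, no change beyond the scatter is expected in this assay and no direction can be firmly expected. The estimated step is a 1.7-fold higher number from compound 2 to compound 3 (0.23 log units; within the scatter) and it is expected to stay within the scatter. Compound 3 is expected at 12 nM with an estimated range from 4 nM to 40 nM in this assay.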

Compound 3, half-maximal inhibitory concentration: 79 nM
For compound 3 the middle estimate is 6.6-fold (0.82 log units) below the measured one; the whole stated range lies below it.
By their numbers in this assay, from the lowest: compounds 2 and 1 (each within the scatter of the next); then compound 3.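

The earlier pair suggested that this carbonyl carbon tolerates change, but in this assay the new result shows that it does not: 4-(trifluoromethyl)phenyl in place of (4-methoxyphenyl)amino gives an 11-fold higher number from compound 2 to compound 3 (1.05 log units; beyond the scatter) and marks a clear loss. The comparison with compound 1 is the more specific finding, as 4-(trifluoromethyl)phenyl in place of 3-(trifluoromethyl)phenyl gives an 8.8-fold higher number from compound 1 to compound 3 (0.94 log units; beyond the scatter) and so separates two groups of the same atom make-up, which shows that the placement of trifluoromethyl on the phenyl ring matters in this series, not just its presence. Nothing available accounts for this loss in potency.

The step from compound 2 to compound 3 changes the amino link and the ring substituent together. The data do not separate these two changes. Going by these compounds, how a plain phenyl, a 4-chlorophenyl or a 4-methoxyphenyl joined directly to the same carbonyl carbon would read also stays open, as does the reading of a (4-(trifluoromethyl)phenyl)amino group there.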